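Series notes: aryloxy in place of alkyl on the core

A few compounds are considered here, and "the series" means these few. Any claim that something is new, unique, unknown or untested is made for them only; others in the source may bear on it.

Compound 3 `COc1cccc(CNCCCNc2ccnc3cc(CC(C)C)ccc23)c1O` gives 4200 nM in a physicochemical assay for solubility, with a stated time of 18 h, at pH 7.4; on this read-out higher numbers stand for higher solubility and lower numbers for lower solubility. Compound 1 `COc1cccc(CNCCCNc2ccnc3cc(Cc4cccc(C(F)(F)F)c4)ccc23)c1O` gives 4200 nM in this assay, and no change at the digits printed from compound 1 to compound 3 (within the scatter), so the two stand together as the lowest of the three numbers. Compound 2 `COc1ccc(Oc2ccc3c(NCCCNCc4cccc(OC)c4O)ccnc3c2)cc1` gives 14500 nM in this assay, the highest of the three: a 3.5-fold higher number from compound 1 to compound 2 (0.54 log units; beyond the scatter) and a 3.5-fold lower number from compound 2 to compound 3 (0.54 log units; beyond the scatter). Compound 4 `COc1ccccc1Oc1ccc2c(NCCCNCc3cccc(OC)c3O)ccnc2c1` is not yet measured; the change is 2-methoxyphenoxy in place of isobutyl on an aromatic carbon. Among the measured compounds shown here, the step from compound 2 to compound 3 bears most directly, being the reverse exchange with a 4-methoxyphenoxy; no measured pair separates 2-methoxyphenoxy from 4-methoxyphenoxy, so that difference is unquantified. Compound 4 is therefore expected to show a 2.9-fold higher number from compound 3 to compound 4 (0.46 log units; beyond the scatter). Compound 4 is estimated at 12000 nM in this assay, range 5000 nM to 30000 nM.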

Compound 4, solubility: 14500 nM
Beside the measured number, compound 4's estimate is 1.2-fold (0.08 log units) below it, within the range that was stated.
By their numbers in this assay, from the lowest: compounds 1 and 3 (each within the scatter of the next); then compounds 2 and 4 (each within the scatter of the next).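

In this assay the two methoxyphenoxy groups on this aromatic carbon read alike, with no change at the digits printed from compound 2 to compound 4 (within the scatter) for 2-methoxyphenyl in place of 4-methoxyphenyl on the oxygen. The higher number therefore recurs with the methoxy group placed differently, giving a 3.5-fold higher number from compound 3 to compound 4 (0.54 log units; beyond the scatter) against isobutyl and a 3.5-fold higher number from compound 1 to compound 4 (0.54 log units; beyond the scatter) against 3-(trifluoromethyl)benzyl. Nothing measured here gives a reason for these steps. Still open, on these data alone, is whether the step needs the methoxy group at all, as an unsubstituted phenoxy would show, and how a phenoxy carrying a carboxylic acid or an amine would read.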